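A few compounds are considered here, and "the series" means these few. Any claim that something is new, unique, unknown or untested is made for them only; others in the source may bear on it.

Of the compounds shown here, two with the same core have been measured. Compound 1 `COc1cc(Cl)cc(-c2nn(-c3cccc(NC(=O)Nc4ccc(Cl)c(C(F)(F)F)c4)c3)cc2-c2ccncc2)c1` carries a urea whose far ring bears both a chloro group and a trifluoromethyl group, while compound 2 `COc1cc(Cl)cc(-c2nn(-c3cccc(NC(=O)Nc4cccc(C(F)(F)F)c4)c3)cc2-c2ccncc2)c1` has hydrogen in place of that chloro group on the aromatic carbon. In a functional assay on NCI-H23 cells (Homo sapiens) for inhibition, read by sulforhodamine B assay, with a stated time of 48 h, tested at 0.1 uM (a higher number here means a weaker effect of the compound at the concentration tested, a lower number a stronger effect), compound 1 gives 90%. In this assay compound 2 gives 90%. Among the compounds with values here, the single measured step is no change at the digits printed from compound 1 to compound 2 (within the scatter), so compound 2 stands level with compound 1, and both sit near the top of the scale, meaning a weak effect at the concentration tested.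

Compound 3 `COc1cc(Cl)cc(-c2nn(-c3cccc(NC(=O)c4cccc(C(F)(F)F)c4)c3)cc2-c2ccncc2)c1` is the next compound. Its difference from compound 2 is 3-(trifluoromethyl)phenyl in place of (3-(trifluoromethyl)phenyl)amino on a carbonyl carbon. In plain terms the urea of compound 2 becomes an amide in compound 3, with one hydrogen-bond donor fewer.

Within the data shown here, only one measured step exists, the one from compound 1 to compound 2, and it changed a different place in the molecule; it was within the scatter. Among the measured compounds shown here, no measured step touches the urea itself. The expected step is therefore no change at the digits printed from compound 2 to compound 3 (within the scatter), nothing beyond the scatter. Compound 3 is expected to give 90%, within a range from 75% to 100%.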

Compound 3, a percentage reported as activity, at one concentration (the size of the read-out at that concentration, not a potency): 97%
Compound 3: the middle estimate sits 7 percentage points below what was measured; low and high end bracket the measured number.
By their numbers in this assay, from the lowest: compounds 1, 2 and 3 (each within the scatter of the next).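

Within the data shown here, this is the first change made at the urea itself. In this assay, turning the urea into an amide, with 3-(trifluoromethyl)phenyl in place of (3-(trifluoromethyl)phenyl)amino on the carbonyl carbon, gives a number 7 percentage points higher from compound 2 to compound 3 (within the scatter). The comparison with the chloro-bearing urea gives a number 7 percentage points higher from compound 1 to compound 3 (within the scatter), so at this position the urea nitrogen and its hydrogen can go without a step beyond the scatter at the one concentration tested. No measurement available here offers an explanation for these values.

All three compounds sit near the top of the scale, where the effect is weak, so these readings cannot show whether urea and amide would separate under conditions where the compounds act more strongly. On these data alone, it also remains open how the numbers would respond to a different link at this place, such as a sulfonamide or a longer chain of methylene groups, or to a carboxylic acid or an amine on the far ring.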